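This account rests on a few compounds, and the source may have more. Where it says the series, first, only, none or still open, it means among the compounds named here.

Compound 1, `NS(=O)(=O)NCC1CCN(c2cc(-c3ccc(Cl)cc3)ncn2)CC1`, in a functional assay on HT-29 cells (Homo sapiens) for antiproliferative activity, read by sulforhodamine B assay, with a stated time of 48 h (on this read-out higher numbers stand for weaker inhibition of growth and lower numbers for stronger inhibition of growth), gives 37700 nM. Compound 3, `NS(=O)(=O)NCC1CCN(c2cc(-c3ccccc3F)ncn2)CC1`, gives 80400 nM in this assay. Compound 2, `NS(=O)(=O)NCC1CCN(c2cc(-c3ccccc3Cl)ncn2)CC1`, reaches only a limit in this assay, > 100000 nM.

Compound 2 therefore stands at the limit of > 100000 nM in this assay, at which 1 of the 3 values shown sits; the step from compound 1 is an at least 2.6-fold higher number from compound 1 to compound 2 (0.42 log units; beyond the scatter), while against compound 3 it is an at least 1.2-fold lower number from compound 2 to compound 3 (0.09 log units; that floor lies within the scatter).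

Compound 4, `NS(=O)(=O)NCCC1CCN(c2cc(-c3ccccc3Cl)ncn2)CC1`, differs from compound 2 by (sulfamoylamino)methyl in place of sulfamoylamino on a saturated chain carbon bound to a saturated ring carbon. Going by the values given here, no measured step touches this chain: the steps known, an at least 2.6-fold higher number from compound 1 to compound 2 (0.42 log units; beyond the scatter) and a 2.1-fold higher number from compound 1 to compound 3 (0.33 log units; beyond the scatter), all concern the aryl ring. With nothing to point elsewhere, the expected step is a step that the limit leaves unreadable from compound 2 to compound 4, none beyond the scatter. Compound 4 is therefore estimated at 150000 nM, within 50000 nM to 400000 nM, most likely again only a limit.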

Compound 4, concentration for 50% growth inhibition: 52900 nM
Estimate against measurement, compound 4: 2.8-fold (0.45 log units) above; measured number inside the range.
By their numbers in this assay, from the lowest: compounds 1, 4 and 3 (each within the scatter of the next, the first and the last beyond it). At a limit, above all of these: compound 2.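

The change to (sulfamoylamino)methyl on a saturated chain carbon bound to a saturated ring carbon is the first shown away from the aryl ring, and in this assay it gives an at least 1.8-fold lower number from compound 2 to compound 4 (0.27 log units; that floor lies within the scatter). Going by these compounds, the true size of this step stays unknown, because compound 2 reaches only a limit: the limit of > 100000 nM in this assay, at which 1 of the 4 values shown sits. With the 2-chlorophenyl group kept, compound 4 gives a number rather than a limit.

On these data alone, whether a longer chain, or an amine or a carboxylic acid in place of the sulfamoylamino group, would give lower numbers remains open. So does whether the same change would act alike with the 4-chlorophenyl group of compound 1.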